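A few compounds are considered here, and "the series" means these few. Any claim that something is new, unique, unknown or untested is made for them only; others in the source may bear on it.

In an ADME assay on HEK293 cells (Homo sapiens) for cytotoxicity, read by MTT assay, with a stated time of 48 h (a higher number here means a weaker inhibitor, a lower number a stronger inhibitor), compound 1 `CN(c1ccc(NC(=O)c2cc(C(F)(F)F)cc(C(F)(F)F)c2)cc1OCc1cccc(C(F)(F)F)c1)S(C)(=O)=O` gives > 500000 nM, which is a limit of the assay and not a number. Compound 2 `Cc1ccc(C(F)(F)F)cc1COc1cc(NC(=O)c2cc(C(F)(F)F)cc(C(F)(F)F)c2)ccc1N(C)S(C)(=O)=O` likewise gives > 500000 nM, again a limit. For the measured compounds named here, compound 3 `CN(c1ccc(NC(=O)c2cc(C(F)(F)F)cc(C(F)(F)F)c2)cc1OCc1cccc(C(F)(F)F)c1)S(=O)(=O)Cc1ccccc1` gives 59800 nM, the only number among the three values shown, the other two sitting at the limit of > 500000 nM in this assay, at which 2 of the 3 values shown sit. The step that the two limits leave unreadable from compound 1 to compound 2 is unreadable, whereas the step of an at least 8.3-fold lower number from compound 1 to compound 3 (0.92 log units; beyond the scatter) is at least modest. Compound 4 `CN(c1ccc(NC(=O)c2cc(C(F)(F)F)cc(C(F)(F)F)c2)cc1OCc1ccc(C(F)(F)F)cc1)S(=O)(=O)Cc1ccccc1` differs from compound 3 by 4-(trifluoromethyl)phenyl in place of 3-(trifluoromethyl)phenyl on a saturated chain carbon bound to an oxygen on an aromatic ring. Going by the values given here, no readable step touches that part of the molecule: the only change at the (3-(trifluoromethyl)benzyl)oxy group, a step that the two limits leave unreadable from compound 1 to compound 2, lies between two limits, and the readable step varies the sulfonyl substituent, which compound 3 and compound 4 share. Compound 4 is therefore expected to show a step of a 1.0-fold higher number from compound 3 to compound 4 (0.00 log units; within the scatter) in this assay, nothing beyond the scatter. Compound 4 is estimated at 60000 nM, between 25000 nM and 150000 nM.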

Compound 4, half-maximal inhibitory concentration: 293000 nM
Compound 4: middle estimate off by 4.9-fold (0.69 log units), on the low side, and the stated range ends below it.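

Exchanging 3-(trifluoromethyl)phenyl for 4-(trifluoromethyl)phenyl on the saturated chain carbon bound to an oxygen on an aromatic ring gives a 4.9-fold higher number from compound 3 to compound 4 (0.69 log units; beyond the scatter) in this assay. For the compounds shown here, this is the first readable step at this position, as the earlier change there cannot be read, and it shows that the same atoms, joined differently, move the number beyond the scatter. With phenyl on the saturated chain carbon bound to a sulfonyl sulfur, this position can be read, whereas compound 1 and compound 2 each stand at a limit of the assay, not a number: the limit of > 500000 nM in this assay, at which 2 of the 4 values shown sit.

The compounds shown leave open whether a chlorine or a methoxy group in place of trifluoromethyl on that ring would read closer to compound 3 or to compound 4. They also leave open whether the same exchange would give a similar step with an ethyl chain on the sulfonyl.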